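Methoxy to acetyl on the shared core: working notes

The source may report more compounds than this note shows. Statements on the series, on what has been measured and on what is new or still open speak of the compounds shown alone.

Measured so far:
- compound 1, `COc1cccc(Nc2nccc(-c3cccnc3)n2)c1`, in a functional assay for inhibition, with Homo sapiens as the target (on this read-out lower numbers stand for stronger inhibition and higher numbers for weaker inhibition), gives 300 nM
- compound 2, `CC(=O)c1cccc(Nc2nccc(-c3cccnc3)n2)c1`, in this assay gives 4100 nM
- compound 3, `COc1ccc(Nc2nccc(-c3cccnc3)n2)cc1`, in this assay gives 1700 nM

Among the compounds with values here, the one single-point step measured so far is a 14-fold higher number from compound 1 to compound 2 (1.14 log units; beyond the scatter), the change being (acetyl in place of methoxy on an aromatic carbon). Compound 3 shares the same atoms as compound 1 joined differently; the difference between the two cores is not broken down here, and the two values simply show compound 3 sitting well higher than compound 1 in this assay.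

Compound 4, `CC(=O)c1ccc(Nc2nccc(-c3cccnc3)n2)cc1`, is not yet measured. Relative to compound 3 the change is acetyl in place of methoxy on an aromatic carbon. Within the data shown here, this is the same kind of change as the one from compound 1 to compound 2, not the same: there the group sits meta to a large group, here para to a large group. Among the measured compounds shown here, whether the size of the step carries over across that difference in place is untested, as only one instance of the step exists.

For the measured compounds named here, compound 4 is expected to move by an 8.8-fold higher number from compound 3 to compound 4 (0.95 log units; beyond the scatter), an expectation that rests on the single measured step of a 14-fold higher number from compound 1 to compound 2 (1.14 log units; beyond the scatter), tempered for the different place. Compound 4 is therefore estimated at 15000 nM in this assay. For compound 4 the expected range runs from 4000 nM to 60000 nM, with a real chance the assay returns only a limit.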

Compound 4, half-maximal inhibitory concentration: 800 nM
Beside the measured number, compound 4's estimate is 19-fold (1.27 log units) above it, and the stated range ends above it.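

Acetyl in place of methoxy on an aromatic carbon, para to a large group, gives a 2.1-fold lower number from compound 3 to compound 4 (0.33 log units; beyond the scatter), so on the core of compound 3 the change goes with stronger inhibition, whereas on the core of compound 1 it goes with weaker inhibition. Neither the size nor the direction of the step carries from one core to the other in this assay: the same change on two cores in this assay, a 14-fold higher number (1.14 log units; beyond the scatter) from compound 1 to compound 2 and a 2.1-fold lower number (0.33 log units; beyond the scatter) from compound 3 to compound 4, 29-fold (1.46 log units) apart, beyond the scatter of two such steps. Not shown is what in the two cores sets this gap: only two instances of the change exist, the place of the group cannot be separated from the core in them, and neither instance gives a rule for any further core in the series.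

The compounds shown leave open whether the split between the two cores belongs to acetyl and methoxy alone or also appears with other groups, such as an amine, a carboxylic acid or a longer chain, in the same places. Also open, on these data alone, is whether any such group would follow the core of compound 1, follow the core of compound 3, or give steps of similar direction on both, which would be needed before any single step could be read across this series.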